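The source may report more compounds than this note shows. Statements on the series, on what has been measured and on what is new or still open speak of the compounds shown alone.

Compound 2 `COc1cccc(N2C(=O)COc3ccc(-c4cccc(NS(=O)(=O)c5ccc(F)cc5)c4)cc32)c1` carries a 3-methoxyphenyl group on the ring nitrogen of its shared core. In a functional assay on HCT-116 cells (Homo sapiens) for antiproliferative activity, read by MTT assay, with a stated time of 72 h (a higher number here means a weaker inhibitor, a lower number a stronger inhibitor), compound 2 gives only a limit of > 40000 nM. Compound 1 `O=C1COc2ccc(-c3cccc(NS(=O)(=O)c4ccc(F)cc4)c3)cc2N1` has the same core with a hydrogen in that place. In this assay compound 1 likewise gives a limit of > 40000 nM. The change hydrogen in place of 3-methoxyphenyl on an amide-type nitrogen in a ring therefore produced a step that the two limits leave unreadable from compound 2 to compound 1, since both ends sit at the limit of > 40000 nM in this assay, at which 2 of the 3 values shown sit.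

Compound 3 `COc1cccc(N2C(=O)COc3ccc(-c4ccc(O)cc4)cc32)c1` keeps the 3-methoxyphenyl group but carries a different outer part; how its core differs from that of compound 2 is not broken down here. In this assay, for the measured compounds named here, compound 3 gives 15300 nM, the only numerical value among the three.

Compound 4 `O=C1COc2ccc(-c3ccc(O)cc3)cc2N1` is not yet measured. It differs from compound 3 by hydrogen in place of 3-methoxyphenyl on an amide-type nitrogen in a ring, the same change as between compound 2 and compound 1. The measured version of this step is unreadable, so the expectation for compound 4 rests only on the value of compound 3, which is already weak. The expected step is a 1.6-fold higher number from compound 3 to compound 4 (0.21 log units; within the scatter), with a fair chance that only a limit is reported. For compound 4 an activity of about 25000 nM is expected, within a range of 8000 nM to 80000 nM.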

Compound 4, half-maximal inhibitory concentration: > 40000 nM
Compound 4: a limit, no number; the forecaster's own chance of this, stated with the estimate: 40%; middle value at least 1.6-fold (0.20 log units) away from the limit.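

Compound 3 gives 15300 nM in this assay, and hydrogen in place of 3-methoxyphenyl on the amide-type nitrogen then gives an at least 2.6-fold higher number from compound 3 to compound 4 (0.41 log units; beyond the scatter), so with this outer part the 3-methoxyphenyl group goes along with measurable activity, though that activity is weak. Compound 4 gives only a limit, so this step has a known minimum but no known size. The same change with the other outer part cannot be read, so these compounds do not show that the effect carries from one core to another, as both ends of that pair and compound 4 rest on the same limit: the limit of > 40000 nM in this assay, at which 3 of the 4 values shown sit.

The compounds shown leave open whether the 3-methoxyphenyl group itself matters or whether any group on that nitrogen would serve, as only hydrogen stands in its place here. A methyl group, or a longer chain ending in an amine or a carboxylic acid, would help to separate these two readings.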